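A few compounds are considered here, and "the series" means these few. Any claim that something is new, unique, unknown or untested is made for them only; others in the source may bear on it.

Working notes on the series. In an ADME assay on a cell-free system (plasma, Homo sapiens) for metabolic stability, read by LC-MS (on this read-out lower numbers stand for a shorter-lived compound and higher numbers for a longer-lived compound), compound 1 (`CCCOC(=O)c1cccc(C(=O)Nc2cccc(-c3cc(C(=O)Nc4ccncc4F)ccc3CN)c2)c1`) gives < 0.0834 h, which is a limit. Compound 2 (`NCc1ccc(C(=O)Nc2ccncc2F)cc1-c1cccc(NC(=O)c2cc(C(=O)O)ccc2F)c1`) gives > 2 h, also a limit. Compound 3 (`NCc1ccc(C(=O)Nc2ccncc2F)cc1-c1cccc(C(=O)Nc2cccc(CC(=O)O)c2)c1`) gives > 2 h, again a limit, and so stands with compound 2 at the limit of > 2 h in this assay, at which 2 of the 3 values shown sit.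

The change to compound 4 (`NCc1ccc(C(=O)Nc2ccncc2F)cc1-c1cccc(C(=O)Nc2cccc(C(=O)O)c2F)c1`) is 3-carboxy-2-fluorophenyl in place of 3-(carboxymethyl)phenyl on an amide-type nitrogen. Among the measured compounds shown here, the one measured step that bears on it is an at least 23-fold higher number from compound 1 to compound 2 (1.37 log units; beyond the scatter), large and beyond the scatter, with 5-carboxy-2-fluorophenyl in place of 3-(propoxycarbonyl)phenyl on a carbonyl carbon. That step does not match the present change, since compound 3 already carries a carboxy group and compound 4 keeps one. Among the three measured compounds, neither carboxy-bearing compound falls short of that limit, and none goes against this.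

No step beyond the scatter is therefore expected in this assay, in either direction, and a further limit is the likeliest report. The expected change is a step that the limit leaves unreadable from compound 3 to compound 4. For compound 4 the estimated half-life is 3 h, with an expected range of 1.5 h to 6 h.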

Compound 4, half-life: > 2 h
Compound 4: a limit, no number; the forecaster's own chance of this, stated with the estimate: 80%; the middle value does not contradict the limit.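

Compound 3 gives > 2 h, a limit. Compound 4 gives > 2 h, also a limit, so no step can be read between the two. On these data alone, whether 3-carboxy-2-fluorophenyl and 3-(carboxymethyl)phenyl on an amide-type nitrogen differ at all in this assay stays open.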